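The compounds below may be only part of what the source reports. "The series", "measured", "known", "first", "only" and "open" are said of these compounds alone.

Three compounds have numbers in a functional assay on CHO cells for agonist activity at metabotropic glutamate receptor 2 (Homo sapiens); on this read-out lower numbers stand for smaller maximal responses and higher numbers for larger maximal responses. Compound 1 `FC(F)(F)Cc1cnc2c(Cl)c(-c3cc(Cl)c4c(ccn4CC4CC4)c3)ccn12` gives 193% in this assay. Compound 2 `N#Cc1c(-c2ccc3c(ccn3C3CCOCC3)c2)ccn2c(CC(F)(F)F)cnc12` gives 442% in this assay, and compound 3 `N#Cc1c(-c2ccc3c(c2)OCCNC3)ccn2c(CC(F)(F)F)cnc12` gives 105% in this assay. Among these three numbers compound 1 stands second highest: compound 3 lies nearest, beyond the scatter below it, and compound 2 lies furthest, beyond the scatter above it. Compound 4 `FC(F)(F)Cc1cnc2c(Cl)c(-c3cc(Cl)c4[nH]ccc4c3)ccn12` has not yet been measured. It differs from compound 1 in one place (hydrogen in place of cyclopropylmethyl on an aromatic nitrogen). Going by the values given here, no measured pair shows this change, so its effect is not known from the data; a step of moderate size is expected, pointing downward, as a number 63 percentage points lower from compound 1 to compound 4 (beyond the scatter) in this assay. Compound 4 is therefore estimated to give 130% in this assay, within a range from 60% to 260%.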

Compound 4, largest response reached (Emax), in percent of the reference or control that the assay uses: 217%
The estimate for compound 4 lay 87 percentage points below the measured number, within the range that was stated.
By their numbers in this assay, from the lowest: compound 3; then compound 1; then compound 4; then compound 2.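

In this assay, going by these compounds alone, replacing cyclopropylmethyl with hydrogen on the aromatic nitrogen gives a number 24 percentage points higher from compound 1 to compound 4 (beyond the scatter), the first reading of this change. Within this pair, the cyclopropylmethyl group is therefore not required for a large maximal response. Nothing available explains the modest rise. The compounds shown leave open how a methyl group, a longer chain or a chain ending in an amine would behave on this nitrogen. They also leave open whether the same change would give a similar step in compounds carrying a nitrile on the core.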